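A Carbamate Replaces the Chlorophenoxypropyl Chain

The compounds below may be only part of what the source reports. "The series", "measured", "known", "first", "only" and "open" are said of these compounds alone.

Of the compounds shown here, two sharing one core have been measured in a functional assay on PANC-1 cells (Homo sapiens) for inhibition, read by MTT assay, with a stated time of 24 h, tested at 10 uM; on this read-out lower numbers stand for less inhibition and higher numbers for more inhibition at the one concentration tested (going by the name of the read-out). Compound 1 `CC(C)=CCC/C(C)=C/CC1Cc2c(OCCCNC(=O)c3ccco3)cc(=O)n(CCCO)c2CC1(C)C` gives 2.8% in this assay. Compound 2 `CC(C)=CCC/C(C)=C/CC1Cc2c(OCCCOc3ccc(Cl)cc3)cc(=O)n(CCCO)c2CC1(C)C` gives 0% in this assay. The two numbers are separated only by a number 2.8 percentage points lower from compound 1 to compound 2 (within the scatter), so compound 2 stands together with compound 1, and there is no other measured number to place it against.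

Compound 3 `CC(C)=CCC/C(C)=C/CC1Cc2c(OC(=O)Nc3ccc(F)cc3F)cc(=O)n(CCCO)c2CC1(C)C` is the next step. Compared with compound 2 it carries (2,4-difluorophenyl)carbamoyl in place of 3-(4-chlorophenoxy)propyl on an oxygen on an aromatic ring. Among the measured compounds shown here, the single measured step, a number 2.8 percentage points lower from compound 1 to compound 2 (within the scatter), exchanged 4-chlorophenoxy for ((furan-2-yl)carbonyl)amino on the saturated chain and left the reading flat. No measured pair changes the group on the ring oxygen itself, so the (2,4-difluorophenyl)carbamoyl group has no direct precedent among the numbers shown. For the measured compounds named here, with both measured compounds near zero and the one known step flat, the expectation for compound 3 is a step of a number 3 percentage points higher from compound 2 to compound 3 (within the scatter) in this assay, meaning no change beyond the scatter. Compound 3 is therefore estimated at 3%, with a range from 0% to 15%.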

Compound 3, a percentage reported as inhibition, at one concentration (the size of the read-out at that concentration, not a potency): 15.6%
Estimate against measurement, compound 3: 12.6 percentage points below, outside the stated range (above it).
By their numbers in this assay, from the lowest: compounds 2 and 1 (each within the scatter of the next); then compound 3.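

The group on the oxygen on an aromatic ring does move the reading in this assay, with a number 15.6 percentage points higher from compound 2 to compound 3 (beyond the scatter) and a number 12.8 percentage points higher from compound 1 to compound 3 (beyond the scatter), whereas the earlier step, which changed only the far end of the propyl chain, stayed within the scatter. Replacing the whole chain with (2,4-difluorophenyl)carbamoyl leaves the count of heavy atoms and the single six-membered aromatic ring unchanged, but it adds a hydrogen-bond donor and a double bond outside aromatic rings, and it swaps chlorine for fluorine, so these counts alone do not account for the rise. Nothing available explains why the number rose.

The carbamoyl link and the 2,4-difluorophenyl ring arrive together, so the rise cannot yet be assigned to either one, and a phenylcarbamoyl or (4-chlorophenyl)carbamoyl group on the same oxygen would help separate them. On these data alone, whether a longer chain between the carbamoyl group and the ring would keep the gain also remains open, and a reading at one concentration gives no potency for compound 3 .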